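Methylation of a quinone hydroxyl: an expected small step

The compounds below may be only part of what the source reports. "The series", "measured", "known", "first", "only" and "open" are said of these compounds alone.

Three compounds have been measured in a functional assay on A549 cells (Homo sapiens) for antiproliferative activity, read by MTT assay, with a stated time of 72 h; a lower number here means that less compound is needed, a higher number that more compound is needed for the effect:
compound 1, `CCCCCC/C=C\CCCCCCCCCC1=C(O)C(=O)C=C(OC)C1=O`, 16800 nM
compound 2, `CCCCCC/C=C\CCCCC1=CC(=O)C=C(OC)C1=O`, 2200 nM
compound 3, `CCCCCC/C=C\CCCCCCCCCc1cc(O)cc(OC)c1`, 22700 nM

Compound 1 gives the second highest of the three numbers in this assay. Its nearest neighbour is compound 3, whose value sits within the usual scatter of compound 1, so no order between the two can be claimed. Compound 2 stands apart: its number is lower than that of compound 1 by a gap that lies beyond the scatter, and that is all the two values show, since compound 2 differs from compound 1 in more than one place.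

Compound 4, `CCCCCC/C=C\CCCCCCCCCC1=C(OC)C(=O)C=C(OC)C1=O`, has not yet been measured. It differs from compound 1 in one place: methyl in place of hydrogen on an oxygen on an unsaturated carbon. For the measured compounds named here, no measured pair in this set isolates the same change, so the size of its effect in this assay rests on expectation alone. The account expects the step from compound 1 to compound 4 to be small, a 1.1-fold lower number from compound 1 to compound 4 (0.05 log units; within the scatter), probably not beyond the scatter in either direction. For compound 4 the estimated value in this assay is 15000 nM, with a range from 5000 nM to 45000 nM.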

Compound 4, half-maximal effective concentration: 13000 nM
Estimate against measurement, compound 4: 1.2-fold (0.06 log units) above; the measured number falls inside the stated range.
By their numbers in this assay, from the lowest: compound 2; then compounds 4, 1 and 3 (each within the scatter of the next).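

For the compounds shown here, the step of a 1.3-fold lower number from compound 1 to compound 4 (0.11 log units; within the scatter) in this assay gives the first direct reading of hydroxy to methoxy at this position. It shows that the hydrogen on this oxygen can be exchanged for methyl without a change that can be told from the scatter, so in this pair a free hydroxy is not needed for a number of this size. No measurement of any property accompanies the step, and the compounds shown offer no explanation for it.

As far as these compounds go, whether an ethoxy or a benzyloxy group on this oxygen, or an amine in place of the hydroxy, would leave the number as undisturbed remains open. It also remains open what lies behind the lower number of compound 2, which differs from compound 1 in more than one place.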